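The source may hold more compounds than are shown below. What is called first, only, known or untested is meant among the compounds shown, and "the series" means these compounds.

Compound 1 `CCCn1c(=O)[nH]c2nc(-c3ccc(S(=O)(=O)N4CCN(c5ccc(Cl)cc5F)CC4)cc3)[nH]c2c1=O`, in an assay on CHO cells for displacement of a labelled ligand from adenosine receptor A3 (Homo sapiens), read by scintillation counting, with a stated time of 45 min, tested at 1 uM, in the presence of a further agent that is not named here (on this read-out lower numbers stand for less inhibition and higher numbers for more inhibition at the one concentration tested (going by the name of the read-out)), compound 1 gives 14%.
Compound 2 `CCCn1c(=O)[nH]c2nc(-c3ccc(S(=O)(=O)N4CCN(c5ccc(Br)cc5)CC4)cc3)[nH]c2c1=O`, in this assay compound 2 gives 29%.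
Compound 3 `CCCn1c(=O)[nH]c2nc(-c3ccc(S(=O)(=O)N4CCN(Cc5ccc(Br)c(F)c5)CC4)cc3)[nH]c2c1=O`, in this assay compound 3 gives 27%.

Compound 3 stands second highest of the three numbers. Its nearest neighbour is compound 2, and the step between them, a number 2 percentage points lower from compound 2 to compound 3 (within the scatter), lies within the scatter, so the two cannot be ordered. Its furthest neighbour is compound 1, and the step of a number 13 percentage points higher from compound 1 to compound 3 (beyond the scatter) lies beyond the scatter.

Compound 4 `CCCn1c(=O)[nH]c2nc(-c3ccc(S(=O)(=O)N4CCN(Cc5ccc(Br)cc5)CC4)cc3)[nH]c2c1=O` differs from compound 3 in one place: hydrogen in place of fluoro on an aromatic carbon. Among the compounds with values here, no measured step removes a fluoro group from this ring, so the expectation rests on neighbours. The step of a number 2 percentage points lower from compound 2 to compound 3 (within the scatter), which exchanges the whole group on the amine nitrogen, stayed within the scatter, and the step of a number 15 percentage points higher from compound 1 to compound 2 (beyond the scatter), which also changed the halogen pattern, was only modest. A single fluoro removed is a smaller change than either. Compound 4 is therefore expected to sit close to compound 3, with a step of a number 1 percentage points lower from compound 3 to compound 4 (within the scatter) that stays within the scatter. The estimate for compound 4 in this assay is 26%, within a range from 12% to 40%.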

Compound 4, a percentage reported as inhibition, at one concentration (the size of the read-out at that concentration, not a potency): 28%
For compound 4 the middle estimate is 2 percentage points below the measured one, and the stated range covers the measured number.
By their numbers in this assay, from the lowest: compound 1; then compounds 3, 4 and 2 (each within the scatter of the next).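

In this assay, the fluoro group on the aromatic carbon ortho to a bromo group can be replaced by hydrogen without a readable change, the step being a number 1 percentage points higher from compound 3 to compound 4 (within the scatter) and so giving no sign that this fluoro group matters on the benzyl ring. Within the data shown here, compound 4 also gives the first comparison of 4-bromobenzyl and 4-bromophenyl on the amine nitrogen with no fluoro group involved, and a number 1 percentage points lower from compound 2 to compound 4 (within the scatter) means that the two cannot be told apart here. The step of a number 14 percentage points higher from compound 1 to compound 4 (beyond the scatter) is modest but beyond the scatter, leaving compound 1, with its 4-chloro-2-fluorophenyl group, as the only one of the four set apart from the rest.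

The compounds shown leave open whether the difference at compound 1 follows from its chloro group or from its fluoro group, and how an amine or a carboxylic acid in place of the bromo group, or a phenethyl group on the amine nitrogen, would read in this test at the one concentration. Nothing available here explains the numbers at this position.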